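The source may report more compounds than this note shows. Statements on the series, on what has been measured and on what is new or still open speak of the compounds shown alone.

Working notes on the series. In an ADME assay on cells (Fibroblast) for cytotoxicity (on this read-out higher numbers stand for weaker inhibition and lower numbers for stronger inhibition), compound 1 (`CN(C)c1ccc(C(=O)N[C@@H](CSCCCC(=O)NO)C(=O)NCc2ccccc2)cc1`) gives 350 nM and compound 2 (`CN(C)c1ccc(NC(=O)[C@H](CSCCCC(=O)NO)NC(=O)c2ccc(N(C)C)cc2)cc1`) gives 600 nM. Among the compounds with values here, these are the only two numbers so far, and they lie within the scatter of each other, so compound 2 cannot be ranked against compound 1.

Compound 3 (`CN(C)c1ccc(C(=O)N[C@@H](CSCCCC(=O)NO)C(=O)NC2CCCc3ccccc32)cc1`) is unmeasured. It carries 1,2,3,4-tetrahydronaphthalen-1-yl in place of the 4-(dimethylamino)phenyl of compound 2 on an amide-type nitrogen: 1,2,3,4-tetrahydronaphthalen-1-yl in place of 4-(dimethylamino)phenyl on an amide-type nitrogen.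

Within the data shown here, one measured step bears on this position: a 1.7-fold higher number from compound 1 to compound 2 (0.23 log units; within the scatter), where 4-(dimethylamino)phenyl replaces benzyl on the same amide-type nitrogen. Among the measured compounds shown here, that is the only evidence on how this assay responds to a change here, and the series holds no measurement with 1,2,3,4-tetrahydronaphthalen-1-yl. With compound 1 at 350 nM and compound 2 at 600 nM, no step beyond the scatter is expected, and the middle is set near these two numbers.

The expected change is a 1.5-fold lower number from compound 2 to compound 3 (0.18 log units; within the scatter), which stays within the scatter.

In this assay the estimate for compound 3 is 400 nM, with an expected range of 150 nM to 1000 nM.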

Compound 3, half-maximal inhibitory concentration: 2200 nM
Compound 3: the middle estimate sits 5.5-fold (0.74 log units) below what was measured; measured number outside the range, above it.
By their numbers in this assay, from the lowest: compounds 1 and 2 (each within the scatter of the next); then compound 3.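

In this assay, the position on this amide-type nitrogen proves able to move the read-out: the change gives a 3.7-fold higher number from compound 2 to compound 3 (0.56 log units; beyond the scatter) and, measured against benzyl, a 6.3-fold higher number from compound 1 to compound 3 (0.80 log units; beyond the scatter), whereas the earlier change between benzyl and 4-(dimethylamino)phenyl stayed within the scatter. 1,2,3,4-tetrahydronaphthalen-1-yl therefore separates from both earlier groups towards weaker inhibition, and the shift does not track the loss of the dimethylamino nitrogen alone, as the benzyl group of compound 1 also lacks that nitrogen and compound 1 still stands apart from compound 3. Nothing at hand accounts for the size or direction of these steps.

As far as these compounds go, it remains open whether the higher number belongs to the saturated ring of 1,2,3,4-tetrahydronaphthalen-1-yl or to the group as a whole. A cyclohexyl group or a 2-phenylethyl chain on the same amide-type nitrogen would help separate these readings, and a primary amine on such a chain would show whether a nitrogen in this group changes the result.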